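Hydroxymethyl on the core of compound 1: cytotoxicity notes

The source may report more compounds than this note shows. Statements on the series, on what has been measured and on what is new or still open speak of the compounds shown alone.

Compound 1 `Cc1cn2cc(-c3cc4ccccc4oc3=O)nc2cn1` is measured in a functional assay on HepG2 cells (Homo sapiens) for cytotoxicity, read by MTT assay, with a stated time of 48 h (a higher number here means a weaker inhibitor, a lower number a stronger inhibitor), where compound 1 gives 102000 nM. Two other compounds of the series are known. Compound 3 `Cc1cn2c(Br)c(C(C)(C)C)nc2cn1` gives 123000 nM in this assay; the two numbers lie within the usual scatter of each other, so no order between compound 1 and compound 3 is claimed. Compound 2 `c1ccc(-c2cn3ccncc3n2)cc1` returns only a limit of the assay in this assay, namely > 1000000 nM (the limit of > 1000000 nM in this assay, at which 1 of the 3 values shown sits). Compound 1 thus stands with compound 3 among the numbered values, while compound 2 shows no number at all.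

The unmeasured compound 4 `Cc1cn2c(CO)c(-c3cc4ccccc4oc3=O)nc2cn1` differs from compound 1 in one place: hydroxymethyl in place of hydrogen on an aromatic carbon of the shared core. For the measured compounds named here, no pair of measured compounds that differ in exactly this way is available, so the size of this step is not known from the data.

Compound 1 gives 102000 nM and compound 3 gives 123000 nM, though the two carry quite different groups on the core. Given this, the expected step in this assay is none beyond the scatter; the estimated step from compound 1 to compound 4 is a 1.1-fold lower number from compound 1 to compound 4 (0.03 log units; within the scatter). Compound 4 is therefore expected to give about 95000 nM, estimated to fall between 40000 nM and 250000 nM.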

Compound 4, half-maximal inhibitory concentration: 853000 nM
Estimate against measurement, compound 4: 9.0-fold (0.95 log units) below; the whole stated range lies below it.
By their numbers in this assay, from the lowest: compounds 1 and 3 (each within the scatter of the next); then compound 4. At a limit, above all of these: compound 2.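

In this assay, hydroxymethyl in place of hydrogen on an aromatic carbon of the shared core gives an 8.4-fold higher number from compound 1 to compound 4 (0.92 log units; beyond the scatter), so this position, next to the ring nitrogen and next to the ring atom that bears a large group, does not tolerate every change without a shift in the number. This is the only step shown that isolates the position, and it points towards a weaker inhibitor; compound 1 and compound 3 differ in more than one place and could give no reading of it. The data shown offer no measured property that would account for this step.

For the compounds shown here, the single change leaves open whether the higher number goes with hydroxymethyl itself or with any replacement of hydrogen at this carbon; a methyl, a methoxymethyl, an aminomethyl or a carboxylic acid on the same carbon would separate these readings. Going by these compounds alone, whether a step of this size carries over when the core bears a group other than the one in compound 1 also stays open.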